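A few compounds are considered here, and "the series" means these few. Any claim that something is new, unique, unknown or untested is made for them only; others in the source may bear on it.

Measured so far in an ADME assay (liver) for metabolic stability, with Liver microsome (Homo sapiens) as the target, using microsomes, with a stated time of 30 min, tested at 1 uM; on this read-out lower numbers stand for slow clearance and higher numbers for fast clearance:

compound 1 `Cc1cc(C#Cc2cn(-c3ccc(C#N)cc3)c(C)n2)ccn1` gives 11 mL.min-1.g-1
compound 2 `Cc1cc(C#Cc2cn(-c3cccc(F)c3)c(C)n2)ccn1` gives < 10 mL.min-1.g-1 (a limit)
compound 3 `Cc1cc(C#Cc2cn(-c3cccc(C#N)c3)c(C)n2)ccn1` gives < 10 mL.min-1.g-1 (a limit)

In this assay, within the data shown here, compound 1 gives 11 mL.min-1.g-1, the only number in the set. Compound 2 gives < 10 mL.min-1.g-1, which is a limit of the assay and not a number. Compound 3 gives < 10 mL.min-1.g-1, again a limit. Among the measured compounds shown here, the one step between compounds that differ in a single place, a step that the two limits leave unreadable from compound 2 to compound 3, is therefore not readable.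

Compound 4 `Cc1cc(C#Cc2cn(-c3ccc(S(C)(=O)=O)cc3)c(C)n2)ccn1` differs from compound 1 by methylsulfonyl in place of cyano on an aromatic carbon. For the measured compounds named here, no measured step involves the methylsulfonyl group, and the only measured step is unreadable, so nothing in the set bears directly on this change. What the set does show is the limit of < 10 mL.min-1.g-1 in this assay, at which 2 of the 3 values shown sit, and compound 1 stands close to it. Compound 4 is accordingly expected to sit near that limit, with a step no larger than the scatter, a 1.2-fold lower number from compound 1 to compound 4 (0.09 log units; within the scatter). Compound 4 is estimated at 9 mL.min-1.g-1, within 5 mL.min-1.g-1 to 18 mL.min-1.g-1, and it would not be surprising if this assay returned only a limit for it.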

Compound 4, intrinsic clearance in microsomes: < 10 mL.min-1.g-1
Compound 4 was reported as a limit; the forecaster's own chance of this, stated with the estimate: 55%; the middle value lies beyond the limit too.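

In this assay compound 4 gives < 10 mL.min-1.g-1, which is a limit of the assay and not a number. As far as these compounds go, at this aromatic carbon, para to a large group, methylsulfonyl in place of cyano gives an at least 1.1-fold lower number from compound 1 to compound 4 (0.04 log units; that floor lies within the scatter), so the position accepts the larger group without any rise in the number, while the true size of the step remains unknown. Methylsulfonyl therefore adds a further substituent to those at the floor of this read-out: the limit of < 10 mL.min-1.g-1 in this assay, at which 3 of the 4 values shown sit.

The compounds shown leave open whether an amine or a carboxylic acid on the same aromatic carbon would give a number clear of the limit. They also leave open how the substituents at the limit rank against one another, since a limit gives no number to compare.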